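Series notes: methyl position on the benzyl substituent

The source may report more compounds than this note shows. Statements on the series, on what has been measured and on what is new or still open speak of the compounds shown alone.

Measured so far in a functional assay on KB cells (Homo sapiens) for cytotoxicity; on this read-out higher numbers stand for weaker inhibition and lower numbers for stronger inhibition:
Compound 1, `Cc1ccc(Cn2cc(C(=N)S)c3c(N)ncnc32)cc1`, 65000 nM
Compound 2, `NC(=S)c1cn(COCc2ccccc2)c2ncnc(N)c12`, > 100000 nM
Compound 3, `NC(=S)c1cn(COCCO)c2ncnc(N)c12`, 115000 nM

The value of compound 2 in this assay is a limit and not a number; this is the limit of > 100000 nM in this assay, at which 1 of the 3 values shown sits. Among the two numbers shown, compound 1 gives the lowest, and compound 3 lies nearest to it, a gap within the usual scatter, so neither can be called the more potent. Going by the values given here, the one measured step, a step that the limit leaves unreadable from compound 2 to compound 3, starts from a limit and its size cannot be read.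

Compound 4, `Cc1ccccc1Cn1cc(C(=N)S)c2c(N)ncnc21`, is not yet measured. It differs from compound 1 by 2-methylphenyl in place of 4-methylphenyl on a saturated chain carbon bound to an aromatic nitrogen. No measured step changes a methylphenyl group in this way; the one step shown concerns another part of the molecule and is unreadable anyway. The expectation for compound 4 therefore rests on compound 1 alone, with a step of no change at the digits printed from compound 1 to compound 4 (within the scatter) expected to stay within the scatter. Compound 4 is estimated at 65000 nM, between 25000 nM and 170000 nM.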

Compound 4, half-maximal inhibitory concentration: > 17000 nM
Compound 4: no number, only a limit; the forecaster's own chance of this, stated with the estimate: 30%; the middle value is on the limit's open side.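

In this assay compound 4 gives > 17000 nM which is a limit and not a number, so the step from compound 1 to compound 4 cannot be read. On these data alone, whether 2-methylphenyl and 4-methylphenyl on this saturated chain carbon differ on this read-out stays open.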